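A few compounds are considered here, and "the series" means these few. Any claim that something is new, unique, unknown or untested is made for them only; others in the source may bear on it.

Measured compounds in an assay on mitochondria for inhibition of Amine oxidase [flavin-containing] B (Rattus norvegicus); a higher number here means a weaker inhibitor, a lower number a stronger inhibitor:

- compound 1, `NC(=O)CNCc1ccc(OCc2cccc(F)c2)cc1`: 2240 nM
- compound 2, `NC(=O)[C@@H](NCc1ccc(OCc2ccccc2)cc1)c1ccccc1`: 73800 nM
- compound 3, `NC(=O)CNCc1ccc(OCc2ccc([N+](=O)[O-])cc2)cc1`: 9100 nM

Compound 2 stands at the highest number of the three and is the weakest inhibitor here; its gap to compound 3 and its larger gap to compound 1 both lie beyond the scatter. Compound 2 differs from compound 1 and compound 3 in carrying a phenyl on the saturated chain carbon bound to the amine nitrogen and the carbonyl carbon, while the other two carry only hydrogen there, together with a different group on the benzyl ether ring.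

Compound 4, `NC(=O)[C@H](CO)NCc1ccc(OCc2ccccc2)cc1`, not yet measured, follows compound 2 with one change: hydroxymethyl in place of phenyl on a saturated chain carbon bound to an amine nitrogen and a carbonyl carbon. Going by the values given here, no measured pair isolates this change. Since the two compounds without a group on that carbon, compound 1 and compound 3, give lower numbers, the step from compound 2 to compound 4 is expected to lower the number beyond the scatter, but not to reach them, estimated at a 4.9-fold lower number from compound 2 to compound 4 (0.69 log units; beyond the scatter). For compound 4 the expected value in this assay is 15000 nM, with a range from 4000 nM to 50000 nM.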

Compound 4, half-maximal inhibitory concentration: 410 nM
Beside the measured number, compound 4's estimate is 37-fold (1.56 log units) above it; measured number below the stated range.
By their numbers in this assay, from the lowest: compound 4; then compound 1; then compound 3; then compound 2.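

At this saturated chain carbon bound to an amine nitrogen and a carbonyl carbon, the choice of group matters greatly in this assay: hydroxymethyl in place of phenyl gives a 180-fold lower number from compound 2 to compound 4 (2.26 log units; beyond the scatter). The high number of compound 2 is therefore tied to phenyl itself, not to the mere presence of a group on this carbon. Nothing available explains the size of this step.

This single change removes an aromatic ring and also brings in a hydrogen-bond donor and acceptor, so the compounds shown cannot tell which of these matters. Methyl on the same carbon would separate loss of the ring from gain of the hydroxyl, while a longer hydroxyalkyl chain such as hydroxyethyl would test how far the result extends beyond hydroxymethyl.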